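The source may report more compounds than this note shows. Statements on the series, on what has been measured and on what is new or still open speak of the compounds shown alone.

Compound 1, `COc1cc(OC)c(OC)cc1/C=C/C1CC=CC(=O)O1`, gives 15.9 uM in a functional assay on HT-29 cells (Homo sapiens) for inhibition, read by sulforhodamine B assay, with a stated time of 48 h; a higher number here means a weaker inhibitor of growth, a lower number a stronger inhibitor of growth. Compound 2, `COc1ccc(/C=C/C2CC=CC(=O)N2)cc1OC`, is a different case: in this assay compound 2 returns only a limit, > 964 uM, so it sits at the limit of > 964 uM in this assay, at which 1 of the 2 values shown sits, rather than at a measured number. Compound 3, `COc1cc(OC)c(OC)cc1/C=C/C1CC=CC(=O)N1`, has not yet been tested in this assay. It differs from compound 2 by one change: methoxy in place of hydrogen on an aromatic carbon. Going by the values given here, the data give no measured step for such a change, so the size of the expected step from compound 2 to compound 3 in this assay is uncertain. Compound 3 is expected to give 600 uM, within 150 uM to 2000 uM, a step of an at least 1.6-fold lower number from compound 2 to compound 3 (0.20 log units; that floor lies within the scatter) that may still end at a limit.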

Compound 3, concentration for growth inhibition (reported as GI): > 864 uM
Compound 3 was reported as a limit; the forecaster's own chance of this, stated with the estimate: 50%; middle value at least 1.4-fold (0.15 log units) from the limit.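

In this assay compound 3 returns only a limit, > 864 uM, so methoxy on this aromatic carbon does not yield a measured number. Compound 2 also stands at a limit, so the step for this change cannot be read. The readable comparison is another one: exchanging the group of 7 heavy atoms with 2 oxygen for the one with 1 nitrogen and 1 oxygen gives an at least 54-fold higher number from compound 1 to compound 3 (1.73 log units; beyond the scatter).

From the compounds shown here alone, whether methoxy here has any effect on growth inhibition remains open. Also open, going by these compounds, is how an amine or a longer chain on this aromatic carbon would behave.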